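Swapping an aryl ether for an aryl thioether on a shared core

The source may report more compounds than this note shows. Statements on the series, on what has been measured and on what is new or still open speak of the compounds shown alone.

Of the compounds shown here, two built on the same fused two-ring core have been tested in a functional assay on NCI-H23 cells (Homo sapiens) for inhibition, read by sulforhodamine B assay, with a stated time of 48 h; on this read-out lower numbers stand for stronger inhibition of growth and higher numbers for weaker inhibition of growth. Compound 1 `Nc1cc(N)c2nc(-c3ccccc3)c(Oc3ccc(F)cc3)nc2c1` gives 20900 nM in this assay, the higher of the two numbers and therefore the weaker growth inhibitor of the pair. Compound 2 `COc1cc(CNc2nc3cc(N)cc(N)c3nc2-c2ccccc2)cc(OC)c1OC` gives 8710 nM in this assay, a number clearly separated from that of compound 1, beyond the usual scatter. The two differ in more than one place, so no single step can be read from them.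

Compound 3 `COc1ccc(Sc2nc3cc(N)cc(N)c3nc2-c2ccccc2)cc1` is not yet measured. It departs from compound 1 in one place: (4-methoxyphenyl)sulfanyl in place of 4-fluorophenoxy on an aromatic carbon. The change sits on an aromatic carbon next to the ring nitrogen and ortho to a phenyl group, the same position that in compound 2 carries a benzylamine chain.

Nothing measured here isolates this swap, so the expectation is cautious. The expected step is a 1.5-fold lower number from compound 1 to compound 3 (0.17 log units; within the scatter), a modest move toward stronger inhibition that may not exceed the scatter. Compound 3 is therefore estimated at 14000 nM, with a likely range from 5000 nM to 40000 nM.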

Compound 3, concentration for 50% growth inhibition: < 100000 nM
Compound 3 ended at the assay's limit; the forecaster's own chance of this, stated with the estimate: 5%; the middle value is on the limit's open side.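

In this assay compound 3 gives < 100000 nM, which is a limit of the assay and not a number. No step between compound 1 and compound 3 can therefore be read, because the only result for compound 3 is this limit: the limit of < 100000 nM in this assay, at which 1 of the 3 values shown sits.

The compounds shown leave open whether (4-methoxyphenyl)sulfanyl in place of 4-fluorophenoxy strengthens or weakens growth inhibition, and by how much.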